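Amide Nitrogen Substituent and Writhing Inhibition: Hexyl to Cyclopentyl

The source may hold more compounds than are shown below. What is called first, only, known or untested is meant among the compounds shown, and "the series" means these compounds.

Measured compounds:
compound 1, `COc1cc2c(cc1OC)C(CC(=O)N(C)C)CC2`: 22.6%
compound 2, `COc1cc2c(cc1OC)C(CC(=O)NC(C)(C)C)CC2`: 41.8%
compound 3, `CCCCCCNC(=O)CC1CCc2cc(OC)c(OC)cc21`: 82.2%

These three amides share one core and differ only in the group on the amide nitrogen. In a functional assay on the whole organism (strain Swiss albino) for inhibition, with Mus musculus as the target, in the writhing test, with stated times of 60 min and 15 min, at a dose of 100 mg/kg by the oral route (a lower number here means less inhibition, a higher number more inhibition at the dose given (going by the name of the read-out)), compound 3 gives the highest of the three numbers; compound 2 lies beyond the scatter below it, and compound 1 lies furthest below. Every measured step concerns that nitrogen: a number 19.2 percentage points higher from compound 1 to compound 2 (beyond the scatter), a number 59.6 percentage points higher from compound 1 to compound 3 (beyond the scatter) and a number 40.4 percentage points higher from compound 2 to compound 3 (beyond the scatter).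

Compound 4, `COc1cc2c(cc1OC)C(CC(=O)NC1CCCC1)CC2`, has not yet been measured. It differs from compound 3 by cyclopentyl in place of hexyl on an amide-type nitrogen. The step that bears most directly on this change is the one in which hexyl replaced tert-butyl, a large gain; the two steps from the dimethylamino compound also show that the group on this nitrogen matters strongly. Cyclopentyl is neither the hexyl chain nor tert-butyl, so the expected number is placed between those of compound 3 and compound 2, meaning a downward step, a number 22.2 percentage points lower from compound 3 to compound 4 (beyond the scatter), is expected. Compound 4 is therefore estimated to give 60%, with a range from 40% to 80%.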

Compound 4, a percentage reported as inhibition, in the whole organism at one dose (the size of the read-out at that dose, not a potency): 37%
For compound 4 the middle estimate is 23 percentage points above the measured one; measured number outside the range, below it.
By their numbers in this assay, from the lowest: compound 1; then compounds 4 and 2 (each within the scatter of the next); then compound 3.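

In this assay, putting a ring of carbon only in place of the open hexyl chain on the amide-type nitrogen is costly, giving a number 45.2 percentage points lower from compound 3 to compound 4 (beyond the scatter). The cyclopentyl amide cannot be told apart from the tert-butyl amide, with a number 4.8 percentage points lower from compound 2 to compound 4 (within the scatter), yet cyclopentylamino in place of dimethylamino still gives a number 14.4 percentage points higher from compound 1 to compound 4 (beyond the scatter), so among these four amides the high number belongs to the hexyl compound alone. Nothing available explains why the open chain stands apart in this way.

On these data alone, whether the high number depends on the open chain itself or on its exact length remains open. A butyl or octyl chain would speak to length, and a cyclohexyl ring would show how a ring with the same carbon count as hexyl compares.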